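This account rests on a few compounds, and the source may have more. Where it says the series, first, only, none or still open, it means among the compounds named here.

Among the compounds with values here, in an assay on isolated protein for inhibition of protein deacetylase HDAC6 (Homo sapiens) (on this read-out higher numbers stand for weaker inhibition and lower numbers for stronger inhibition), compound 2 `O=C(NO)c1ccc(CN2C(=O)/C(=C3\Nc4ccccc4\C3=N/O)c3cc(Br)ccc32)cc1` gives 24 nM, at the low end of the two numbers so far, and compound 1 `O=C(NO)c1ccc(CN2C(=O)/C(=C3\Nc4ccccc4\C3=N/O)c3cc(F)ccc32)cc1` gives 43 nM; the two lie within the scatter of each other. Within the data shown here, the one measured step, a 1.8-fold lower number from compound 1 to compound 2 (0.25 log units; within the scatter), lies within the scatter. Compound 3 `COc1ccc2c(c1)/C(=C1/Nc3ccccc3/C1=N\O)C(=O)N2Cc1ccc(C(=O)NO)cc1` carries methoxy in place of bromo on an aromatic carbon. Among the measured compounds shown here, no measured step exchanges bromo for methoxy, and the one exchange on that aromatic carbon gave no step beyond the scatter. For compound 3 the expected change is therefore a 1.5-fold higher number from compound 2 to compound 3 (0.16 log units; within the scatter), small in either direction. In this assay compound 3 is estimated at 35 nM, within 12 nM to 100 nM.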

Compound 3, half-maximal inhibitory concentration: 30 nM
Beside the measured number, compound 3's estimate is 1.2-fold (0.07 log units) above it; low and high end bracket the measured number.
By their numbers in this assay, from the lowest: compounds 2, 3 and 1 (each within the scatter of the next).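

In this assay methoxy joins bromo and fluoro on this aromatic carbon, with a 1.3-fold higher number from compound 2 to compound 3 (0.10 log units; within the scatter) and a 1.4-fold lower number from compound 1 to compound 3 (0.16 log units; within the scatter) as its two steps. Methoxy brings a hydrogen-bond acceptor and one more heavy atom than bromo, yet both steps, like the exchange of the two halogens, stay within the scatter. No measurement available here explains this flat picture at this position. From the compounds shown here alone, whether an amine, a carboxylic acid or a longer alkoxy chain on this carbon would move the number beyond the scatter remains open.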